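Substituent on the chain carbon bound to ring nitrogen

A few compounds are considered here, and "the series" means these few. Any claim that something is new, unique, unknown or untested is made for them only; others in the source may bear on it.

Measured compounds in a functional assay on the whole organism (B cells) with Mus musculus as the target; on this read-out higher numbers stand for larger maximal responses and lower numbers for smaller maximal responses:
- compound 1, `COc1ccc(Cn2c(=O)n(C3OC(CO)[C@@H](O)[C@H]3O)c3nc(N)nc(O)c32)cc1`, gives 44%
- compound 2, `CN(C)CCCn1c(=O)n(C2OC(CO)[C@@H](O)[C@H]2O)c2nc(N)nc(O)c21`, gives 83%

Compound 2 stands highest of the two measured compounds; its nearest neighbour is compound 1, and the step of a number 39 percentage points higher from compound 1 to compound 2 (beyond the scatter) lies beyond the scatter. Among the measured compounds shown here, that one step is the only measured change at the saturated chain carbon bound to an aromatic nitrogen, and it shows that what sits there can move the maximal response by a large amount.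

Compound 3, `CCOC(=O)Cn1c(=O)n(C2OC(CO)[C@@H](O)[C@H]2O)c2nc(N)nc(O)c21`, is not yet measured. It differs from compound 2 as follows: ethoxycarbonyl in place of 2-(dimethylamino)ethyl on a saturated chain carbon bound to an aromatic nitrogen. For the measured compounds named here, no measured pair shows ethoxycarbonyl at this place, so the direction of the step cannot be taken from the data; the step from compound 1 to compound 2 only says the size may be large. Without a group of the same kind on record, the estimate for compound 3 is set between the two measured values, nearer the middle, with a wide range: compound 3 is expected to give 58%, between 30% and 85%, which is an expected step of a number 25 percentage points lower from compound 2 to compound 3 (beyond the scatter).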

Compound 3, largest response reached (reported as maximal response), in percent of the reference or control that the assay uses: 86%
Compound 3: middle estimate off by 28 percentage points, on the low side, and the stated range ends below it.
By their numbers in this assay, from the lowest: compound 1; then compounds 2 and 3 (each within the scatter of the next).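

this assay gives a number 3 percentage points higher from compound 2 to compound 3 (within the scatter), so on a saturated chain carbon bound to an aromatic nitrogen, the exchange of 2-(dimethylamino)ethyl for ethoxycarbonyl leaves no readable difference, even though the entering group brings a carbonyl and the leaving group's nitrogen is gone. Ethoxycarbonyl in place of 4-methoxyphenyl gives a number 42 percentage points higher from compound 1 to compound 3 (beyond the scatter), so the large difference from compound 1 is no longer tied to the dimethylamino chain alone: among the three compounds, two quite different chains stand together and compound 1 stands apart. Nothing on record accounts for this result.

Still open, from the compounds shown here alone, is whether the separation of compound 1 in this assay goes with the aromatic ring of 4-methoxyphenyl or with its methoxy group, a question that a plain benzyl group or a 4-hydroxybenzyl group would address. Going by these compounds, it is equally open whether the level shared by compound 2 and compound 3 would hold with a free carboxylic acid in place of the ethyl ester, a primary amine in place of the dimethylamino group, or a longer chain.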